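The source may report more compounds than this note shows. Statements on the series, on what has been measured and on what is new or still open speak of the compounds shown alone.

Series notes, values measured in an ADME assay on HepG2 cells (Homo sapiens) for cytotoxicity, read by luminescence, with a stated time of 72 h; on this read-out lower numbers stand for an effect already at smaller amounts and higher numbers for an effect only at larger amounts of compound:

- Compound 1 `CCOC(=O)c1c(-c2cccc(OC)c2)[nH]c2cc(OC)c(OC)cc2c1=O`: > 21500 nM, a limit and not a number.
- Compound 2 `CCOC(=O)c1c(-c2cccc(-c3ccccc3)c2)[nH]c2cc(OC)c(F)cc2c1=O`: > 21500 nM, a limit and not a number.

Compound 2 gives only a limit, > 21500 nM, and has no numerical value to place it in the series. The data so far amount to the limit of > 21500 nM in this assay, at which 2 of the 2 values shown sit. Going by the values given here, no step between measured compounds is available, so the series does not yet show how much a single change moves this assay.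

The next compound is compound 3 `CCOC(=O)c1c(-c2cccc(OC)c2)[nH]c2cc(OC)c(F)cc2c1=O`. It carries methoxy in place of phenyl on an aromatic carbon, meta to a large group, compared with compound 2: methoxy in place of phenyl on an aromatic carbon.

No step beyond the usual scatter is expected in this assay, and no direction is favoured. This expectation rests on compound 2, whose > 21500 nM is a limit. The expected change is a step that the limit leaves unreadable from compound 2 to compound 3, and a further report as a limit is considered the likeliest outcome. For compound 3 the estimate is 25000 nM, with an expected range of 12000 nM to 50000 nM.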

Compound 3, half-maximal effective concentration: > 21500 nM
Compound 3 ended at the assay's limit; the forecaster's own chance of this, stated with the estimate: 85%; the middle value lies beyond the limit too.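

In this assay no step can be read between compound 3 and either compound 1 or compound 2, as each of the three is reported only as a limit: the limit of > 21500 nM in this assay, at which 3 of the 3 values shown sit.

The compounds shown leave open how far any of the three lies beyond that limit, and whether any change on the shared core would give a numerical value.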